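The compounds below may be only part of what the source reports. "The series", "measured", "known", "first", "only" and "open" are said of these compounds alone.

Of the compounds shown here, two have been measured in an ADME assay on HEK293 cells for agonist activity at metabotropic glutamate receptor 5 (Rattus norvegicus), read by fluorescence and calcium flux (a higher number here means a larger maximal response, a lower number a smaller maximal response), so far. Compound 1, `C[C@@H](NC(=O)c1ccc(C#Cc2cc(F)cc(F)c2)cn1)C(C)(C)O`, gives 37.9% in this assay. Going by the values given here, compound 2, `C[C@@H](NC(=O)c1ccc(C#Cc2ccncc2)cn1)C(C)(C)O`, gives 22.4% in this assay, the lower of the two numbers; the only measured step, a number 15.5 percentage points lower from compound 1 to compound 2 (beyond the scatter), separates them and lies beyond the scatter.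

Compound 3, `C[C@@H](NC(=O)c1ccc(C#Cc2ccc(F)cn2)cn1)C(C)(C)O`, has not yet been measured in this assay. It differs from compound 2 in one place: 5-fluoropyridin-2-yl in place of pyridin-4-yl on a triple-bonded carbon

Among the compounds with values here, the single measured step touches the same place, the group on the triple-bonded carbon, and it shows that swapping one ring for another there can move the maximal response by a modest amount. Compound 3 carries a ring that shares the nitrogen of compound 2 and the fluorine of compound 1, so a modest rise is expected, a number 8.6 percentage points higher from compound 2 to compound 3 (within the scatter). Compound 3 is therefore estimated to reach about 31% in this assay, most likely between 16% and 48%.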

Compound 3, largest response reached (reported as efficacy), in percent of the reference or control that the assay uses: 13.5%
Beside the measured number, compound 3's estimate is 17.5 percentage points above it, outside the stated range (below it).
By their numbers in this assay, from the lowest: compounds 3 and 2 (each within the scatter of the next); then compound 1.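

At this place on the triple-bonded carbon, adding a fluorine to a nitrogen-containing ring does not recover the response: in this assay, 5-fluoropyridin-2-yl in place of pyridin-4-yl gives a number 8.9 percentage points lower from compound 2 to compound 3 (within the scatter), so the two compounds cannot be told apart. Set against 3,5-difluorophenyl, the same ring gives a number 24.4 percentage points lower from compound 1 to compound 3 (beyond the scatter), so both nitrogen-containing rings now stand apart from compound 1, not just pyridin-4-yl. No measurement at hand explains these differences.

On these data alone, with three rings, the part played by the ring nitrogen cannot be separated from that of the fluorine atoms, and it remains open whether a plain phenyl ring would read like compound 1 or like compound 2 and compound 3. As far as these compounds go, how a methoxy group or an amine on the ring would read in this assay also remains unknown.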